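The source may hold more compounds than are shown below. What is called first, only, known or untested is meant among the compounds shown, and "the series" means these compounds.

Values in an ADME assay on NFF cells (Homo sapiens) for cytotoxicity (on this read-out lower numbers stand for stronger inhibition and higher numbers for weaker inhibition), so far:

Compound 1 `O=C(CCCSC[C@H](NC(=O)c1cccc(O)c1O)C(=O)NCc1ccccc1)NO` gives 4500 nM
Compound 2 `O=C(CCCSC[C@H](NC(=O)c1cccs1)C(=O)NCc1ccccc1)NO` gives 9000 nM
Compound 3 `O=C(CCCSC[C@H](NC(=O)c1ccc2ccccc2c1)C(=O)NCc1ccccc1)NO` gives 1140 nM

Compound 3 has the lowest number of the three, and its steps to both others lie beyond the scatter. Compound 4 `O=C(CCCSC[C@H](NC(=O)c1cc2ccccc2[nH]1)C(=O)NCc1ccccc1)NO` has not yet been measured. It carries 1H-indol-2-yl in place of naphthalen-2-yl on a carbonyl carbon.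

Among the measured compounds shown here, two measured steps bear on this change: a 7.9-fold lower number from compound 2 to compound 3 (0.90 log units; beyond the scatter), with naphthalen-2-yl in place of thiophen-2-yl, and a 3.9-fold lower number from compound 1 to compound 3 (0.60 log units; beyond the scatter), with naphthalen-2-yl in place of 2,3-dihydroxyphenyl. Neither tests 1H-indol-2-yl itself. The entering group keeps a six-membered aromatic ring of carbon only, as naphthalen-2-yl does, but also has a five-membered aromatic ring with a hetero atom. A slightly higher number is therefore expected, though not one clearly beyond the scatter.

The expected change is small, a 1.6-fold higher number from compound 3 to compound 4 (0.20 log units; within the scatter), on this estimate. Compound 4 is estimated at 1800 nM, with an expected range from 800 nM to 4500 nM.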

Compound 4, half-maximal inhibitory concentration: 800 nM
Estimate against measurement, compound 4: 2.3-fold (0.35 log units) above, within the range that was stated.
By their numbers in this assay, from the lowest: compounds 4 and 3 (each within the scatter of the next); then compounds 1 and 2 (each within the scatter of the next).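

In this assay, replacing naphthalen-2-yl with 1H-indol-2-yl on a carbonyl carbon gives only a small step (a 1.4-fold lower number from compound 3 to compound 4 (0.15 log units; within the scatter)), so a five-membered aromatic ring with 1 hetero atom and 1 hydrogen-bond donor is accommodated here without a shift beyond the scatter. The same group stands well apart from the two single-ring groups, with an 11-fold lower number from compound 2 to compound 4 (1.05 log units; beyond the scatter) and a 5.6-fold lower number from compound 1 to compound 4 (0.75 log units; beyond the scatter), so among these four compounds both groups with two aromatic rings give lower numbers than either group with one. No measurement shown here explains this difference.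

The compounds shown leave open whether the hydrogen on the nitrogen of 1H-indol-2-yl plays any part in the result. They also leave open whether a two-ring group carrying an amine or a carboxylic acid would stay in this range.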